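The source may report more compounds than this note shows. Statements on the series, on what has been measured and on what is new or still open speak of the compounds shown alone.

Compound 2, with the structure `Cc1cc(Nc2cc(Cl)cc(-c3ccc(O)cc3)c2)nc(N)n1`, is the starting point here. In an assay on cells for inhibition of S-adenosylmethionine decarboxylase proenzyme (Homo sapiens), read by mass spectrometry, at pH 7.2 (on this read-out higher numbers stand for weaker inhibition and lower numbers for stronger inhibition), compound 2 gives > 180000 nM, which is a limit of the assay rather than a measured number. Its neighbour compound 1, with the structure `COc1ccc(-c2cc(Cl)cc(Nc3cc(C)nc(N)n3)c2)cc1`, carries a methyl on the oxygen of the aromatic ring where compound 2 carries a hydrogen. In this assay compound 1 also gives only a limit, > 180000 nM. The step that the two limits leave unreadable from compound 1 to compound 2 therefore cannot be read in size, since (the limit of > 180000 nM in this assay, at which 2 of the 2 values shown sit).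

Compound 3, with the structure `Cc1cc(Nc2cc(Cl)cc(-c3cncnc3)c2)nc(N)n1`, is not yet measured. It differs from compound 2 by pyrimidin-5-yl in place of 4-hydroxyphenyl on an aromatic carbon. For the measured compounds named here, no measured step here bears on this change, because the limit of > 180000 nM in this assay, at which 2 of the 2 values shown sit, leaves nothing readable. For compound 3 the expectation therefore rests on nothing more than the limit shared by its two neighbours, and compound 3 is expected to give 180000 nM, within 50000 nM to 600000 nM. The expected step of a number no higher from compound 2 to compound 3 (the limit leaves the size open) is thus no change beyond the scatter.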

Compound 3, half-maximal inhibitory concentration: > 180000 nM
Compound 3 was reported as a limit (the forecaster's own chance of this, stated with the estimate: 80%); the middle value sits exactly at the limit.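

In this assay, for the compounds shown here, compound 3 also gives only a limit, so no step among compound 1, compound 2 and compound 3 can be read in size: the limit of > 180000 nM in this assay, at which 3 of the 3 values shown sit. The compounds shown leave open whether any group on this aromatic carbon gives inhibition that can be measured as a number.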